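Thiopurine ribosides and inhibition of nucleoside transport

The compounds below may be only part of what the source reports. "The series", "measured", "known", "first", "only" and "open" are said of these compounds alone.

Compound 1: `OC[C@H]1O[C@@H](n2cnc3c(SCC4CCCCC4)ncnc32)[C@H](O)[C@@H]1O` — 1550 nM
Compound 2: `OC[C@H]1O[C@@H](n2cnc3c(SCCCc4ccccc4)ncnc32)[C@H](O)[C@@H]1O` — 1350 nM
Compound 3: `OC[C@H]1O[C@@H](n2cnc3c(Sc4ccccc4)ncnc32)[C@H](O)[C@@H]1O` — not yet measured

Going by the values given here, in an assay on isolated protein for binding affinity to Equilibrative nucleoside transporter 1 (Homo sapiens) (a lower number here means a stronger inhibitor, a higher number a weaker inhibitor), compound 2 gives 1350 nM, the lowest of the two numbers so far, with compound 1 standing nearest at 1550 nM. Among the compounds with values here, the only step measured, a 1.1-fold lower number from compound 1 to compound 2 (0.06 log units; within the scatter), lies within the scatter. Compound 3 differs from compound 2 by phenyl in place of 3-phenylpropyl on a sulfur. Within the data shown here, no measured step shortens the chain in this way, so the single step at hand gives little guidance, and a modest loss cannot be ruled out. Compound 3 is therefore expected at 2500 nM, with a range from 600 nM to 10000 nM, the estimated step being a 1.9-fold higher number from compound 2 to compound 3 (0.27 log units; within the scatter).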

Compound 3, half-maximal inhibitory concentration: 91200 nM
Compound 3: the middle estimate sits 36-fold (1.56 log units) below what was measured, outside the stated range (above it).
By their numbers in this assay, from the lowest: compounds 2 and 1 (each within the scatter of the next); then compound 3.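

In this assay, the position on the sulfur proves far from indifferent: phenyl costs heavily against 3-phenylpropyl (a 68-fold higher number from compound 2 to compound 3 (1.83 log units; beyond the scatter)) and against cyclohexylmethyl (a 59-fold higher number from compound 1 to compound 3 (1.77 log units; beyond the scatter)). The two compounds with a saturated chain carbon on the sulfur stay within the scatter of each other, while compound 3, with aromatic carbon there, stands far apart from both. Nothing at hand gives a reason for this loss. Open, going by these compounds, is whether a benzyl group on the sulfur lands near compound 3 or near compound 2. Also open, on these data alone, is whether an amine or a chlorine on the phenyl of compound 3 changes its number.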